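A few compounds are considered here, and "the series" means these few. Any claim that something is new, unique, unknown or untested is made for them only; others in the source may bear on it.

Of the compounds shown here, three have so far been measured in an ADME assay on CHO cells (Cricetulus griseus) for inhibition, read by MTT assay; a lower number here means a stronger inhibitor, a higher number a weaker inhibitor. Compound 1 `Cc1cc(CNC(C)(C)C)c(O)c(Nc2nc3c(Cl)cc(Cl)cc3[nH]2)c1` gives 25800 nM. Compound 2 `CCN(CC)Cc1cc(Nc2nc3ccccc3[nH]2)ccc1O` reaches only a limit of the measurement, > 50000 nM. Compound 3 `CCN(CC)Cc1ccc(C)c(Nc2nc3ccccc3[nH]2)c1O` likewise reaches only a limit, > 50000 nM. Within the data shown here, compound 2 therefore stands at the limit of the measurement, a position it shares with a second value (the limit of > 50000 nM in this assay, at which 2 of the 3 values shown sit), and no step between compounds differing in a single place has been measured. Compound 4 `CCN(CC)Cc1cc(Nc2nc3ccccc3n2Cc2ccc(F)cc2)ccc1O` differs from compound 2 by 4-fluorobenzyl in place of hydrogen on an aromatic nitrogen. Among the measured compounds shown here, no comparable step exists among the measured compounds, so in this assay the change is expected to stay within the scatter, in no clear direction. Compound 4 is expected to give about 60000 nM, within 20000 nM to 150000 nM. The expected step is a step that the limit leaves unreadable from compound 2 to compound 4.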

Compound 4, half-maximal inhibitory concentration: 12000 nM
Estimate against measurement, compound 4: 5.0-fold (0.70 log units) above; the whole stated range lies above it.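

In this assay, 4-fluorobenzyl on the aromatic nitrogen gives an at least 4.1-fold lower number from compound 2 to compound 4 (0.61 log units; beyond the scatter), the first sign among these compounds that a change at this position can move the number. The true size of the step cannot be read, because compound 2 stands at a limit of the measurement: the limit of > 50000 nM in this assay, at which 2 of the 4 values shown sit.

On these data alone, whether the step depends on the fluorine, the aromatic ring or simply any group on this nitrogen stays open. A plain benzyl or a methyl in the same place would help tell these apart.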